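The compounds below may be only part of what the source reports. "The series", "measured", "known", "first", "only" and "open" are said of these compounds alone.

Compound 1 `COc1cc(-c2cc(/C=C/C(=O)c3ccc(N)cc3)[nH]n2)cc(OC)c1OC` is measured in a functional assay on UACC-257 cells (Homo sapiens) for cytotoxicity, read by sulforhodamine B assay, with a stated time of 48 h, tested at 10 uM (a lower number here means a stronger effect, a higher number a weaker effect of the compound at the concentration tested), where compound 1 gives -59%. Going by the values given here, compound 2 `COc1ccc(C(=O)/C=C/c2cc(-c3cc(OC)c(OC)c(OC)c3)n[nH]2)cc1OC` shares the same core and gives -98% in this assay, so compound 2 holds the lower of the two numbers so far, and its only neighbour is compound 1. Among the compounds with values here, the single measured step, a number 39 percentage points lower from compound 1 to compound 2 (beyond the scatter), replaces a whole ring on the carbonyl carbon: 3,4-dimethoxyphenyl in place of 4-aminophenyl. Compound 3 `COc1ccc(C(=O)/C=C/c2cc(-c3cc(OC)c(OC)c(OC)c3)n[nH]2)cc1` differs from compound 2 by hydrogen in place of methoxy on an aromatic carbon, that is, 3,4-dimethoxyphenyl becomes 4-methoxyphenyl, ortho to a methoxy group. Within the data shown here, no measured step removes a single methoxy, so the step from compound 1 to compound 2 bears on it only by showing that this part of the molecule matters. A modest loss of effect is expected, a number 13 percentage points higher from compound 2 to compound 3 (beyond the scatter), near the edge of the scatter. Compound 3 is therefore estimated at -85% in this assay, with a range from -100% to -55%.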

Compound 3, a percentage reported as activity, at one concentration (the size of the read-out at that concentration, not a potency): -65%
Compound 3: the middle estimate sits 20 percentage points below what was measured; low and high end bracket the measured number.
By their numbers in this assay, from the lowest: compound 2; then compounds 3 and 1 (each within the scatter of the next).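

In this assay, taking away the single methoxy ortho to a methoxy group, so that 3,4-dimethoxyphenyl becomes 4-methoxyphenyl, gives a number 33 percentage points higher from compound 2 to compound 3 (beyond the scatter) and shows that this one group, not merely the whole ring, carries a large part of the effect. The other new comparison, methoxy in place of amino on the same ring, gives a number 6 percentage points lower from compound 1 to compound 3 (within the scatter) and so does not separate these two groups in this assay. The large difference seen earlier between the two rings therefore goes with the presence of the second methoxy. Nothing measured here explains why this one group matters so much.
The compounds shown leave open whether a hydroxyl, a chlorine or an ethoxy at this place would match the methoxy of compound 2. They also leave open whether the stronger or weaker effects seen here would hold at other concentrations, as each compound was tested at a single concentration.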